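Tert-butyl Addition on Two Dimethoxy and Dibenzyloxy Cores

A few compounds are considered here, and "the series" means these few. Any claim that something is new, unique, unknown or untested is made for them only; others in the source may bear on it.

Compound 1 `O=C1NC(O)(CCn2cc(-c3ccccc3)nn2)C(OCc2ccccc2)=C1OCc1ccccc1`: 20500 nM
Compound 2 `CC(C)(C)c1ccc(-c2cn(CCC3(O)NC(=O)C(OCc4ccccc4)=C3OCc3ccccc3)nn2)cc1`: 25100 nM
Compound 3 `COC1=C(OC)C(O)(CCn2cc(-c3ccccc3)nn2)NC1=O`: 22600 nM

In a functional assay on MCF7 cells (Homo sapiens) for antiproliferative activity, read by MTT assay, with a stated time of 24 h (a higher number here means a weaker inhibitor, a lower number a stronger inhibitor), compound 1 gives 20500 nM and compound 2 gives 25100 nM. The change between them is tert-butyl in place of hydrogen on an aromatic carbon, and the step it made is a 1.2-fold higher number from compound 1 to compound 2 (0.09 log units; within the scatter). Compound 3 gives 22600 nM in this assay; how its core differs from that of compound 1 is not broken down here, and their two values lie within the usual scatter of each other.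

Compound 4 `COC1=C(OC)C(O)(CCn2cc(-c3ccc(C(C)(C)C)cc3)nn2)NC1=O` is not yet measured. It differs from compound 3 by tert-butyl in place of hydrogen on an aromatic carbon, the same change as that from compound 1 to compound 2. Since that earlier step was a 1.2-fold higher number from compound 1 to compound 2 (0.09 log units; within the scatter), compound 4 is expected to sit close to compound 3, with an estimated step of a 1.2-fold higher number from compound 3 to compound 4 (0.08 log units; within the scatter). The estimate for compound 4 in this assay is 27000 nM, expected between 12000 nM and 60000 nM.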

Compound 4, half-maximal inhibitory concentration: > 100000 nM
Compound 4 gave a limit, no number; the forecaster's own chance of this, stated with the estimate: 10%; middle value at least 3.7-fold (0.56 log units) from the limit.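

Tert-butyl in place of hydrogen on an aromatic carbon gave an at least 4.4-fold higher number from compound 3 to compound 4 (0.64 log units; beyond the scatter) in this assay. The change therefore did not carry over in size from one core to the other: the same change on two cores in this assay, a 1.2-fold higher number (0.09 log units; within the scatter) from compound 1 to compound 2 and an at least 4.4-fold higher number (0.64 log units; beyond the scatter) from compound 3 to compound 4, at least 3.6-fold (0.55 log units) apart, beyond the scatter of two such steps. Compound 4 stands at a limit and not at a number, so the full size of its step stays unknown, and two cores alone do not show why the steps part: the limit of > 100000 nM in this assay, at which 1 of the 4 values shown sits.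

The compounds shown leave open whether a methyl group, a chlorine atom or a carboxylic acid in the same place would also separate the two cores. They also leave open how tert-butyl would behave with ethoxy groups on the core.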